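The source may report more compounds than this note shows. Statements on the series, on what has been measured and on what is new or still open speak of the compounds shown alone.

Compound 1, `Cc1nn(C)c(Oc2ccc(F)cc2)c1/C=N\CCCCCOc1cc2oc(=O)cc(C)c2cc1Cl`: in a functional assay on HepG2 cells (Homo sapiens) for antiproliferative activity, read by MTT assay, with a stated time of 72 h (a lower number here means a stronger inhibitor, a higher number a weaker inhibitor), compound 1 reaches only the assay limit of > 25000 nM, a bound rather than a number.
Compound 2, `Cc1nn(C)c(Oc2ccc(Cl)cc2)c1/C=N\CCCCCOc1cc2oc(=O)cc(C)c2cc1Cl`: in this assay compound 2 gives 15300 nM.
Compound 3, `Cc1nn(C)c(Oc2cccc(Cl)c2)c1/C=N\CCCCCCOc1cc2oc(=O)cc(C)c2cc1Cl`: in this assay compound 3 gives 6220 nM.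

Compound 3 carries the lowest of the two numbers; its gap to compound 2 lies beyond the usual scatter. Compound 4, `Cc1nn(C)c(Oc2cccc(C(F)(F)F)c2)c1/C=N\CCCCCCOc1cc2oc(=O)cc(C)c2cc1Cl`, differs from compound 3 in one place: trifluoromethyl in place of chloro on an aromatic carbon. Among the measured compounds shown here, only one measured step alters the same aromatic ring, an at least 1.6-fold lower number from compound 1 to compound 2 (0.21 log units; that floor lies within the scatter), and that step begins at a limit, (the limit of > 25000 nM in this assay, at which 1 of the 3 values shown sits), so it offers little guidance for replacing chloro with trifluoromethyl. No change beyond the scatter is expected in this assay; the expected step is a 1.0-fold lower number from compound 3 to compound 4 (0.02 log units; within the scatter). Compound 4 is therefore estimated to give 6000 nM, within 2500 nM to 15000 nM.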

Compound 4, half-maximal inhibitory concentration: > 25000 nM
Compound 4 gave a limit, no number; the forecaster's own chance of this, stated with the estimate: 10%; middle value at least 4.1-fold (0.61 log units) away from the limit.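

In this assay, the 3-chlorophenoxy group cannot be changed freely to 3-(trifluoromethyl)phenoxy: the swap gives an at least 4.0-fold higher number from compound 3 to compound 4 (0.60 log units; beyond the scatter). The value of compound 4, > 25000 nM, is a limit, so this step has a floor but no measured size. Unlike the earlier step on this ring, this one starts from a real number, yet its end point joins a growing share of limits in this small set: the limit of > 25000 nM in this assay, at which 2 of the 4 values shown sit.

On these data alone, whether a methoxy group, a nitrile or an amine at this position would give a measurable number stays open. So does whether a longer chain would alter the effect of this change.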